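Swapping furan for indole on the amide carbonyl

The source may hold more compounds than are shown below. What is called first, only, known or untested is meant among the compounds shown, and "the series" means these compounds.

Of the compounds shown here, three sharing one core have been measured in a functional assay on MCF7 cells (Homo sapiens) for antiproliferative activity, read by MTT assay, with a stated time of 72 h; on this read-out higher numbers stand for weaker inhibition and lower numbers for stronger inhibition. Compound 1 `CCN1CCN(c2cc(C)c3cc(NC(=O)c4ccc(Cl)cc4)ccc3n2)CC1` gives 1530 nM. Compound 2 `CCN1CCN(c2cc(C)c3cc(NC(=O)c4cccnc4)ccc3n2)CC1` gives 26600 nM, and compound 3 `CCN1CCN(c2cc(C)c3cc(NC(=O)c4ccco4)ccc3n2)CC1` gives 41200 nM, the highest number of the three; the difference between compound 2 and compound 3 is only a 1.5-fold higher number from compound 2 to compound 3 (0.19 log units; within the scatter), so these two cannot be told apart, whereas a far larger step lies beyond the scatter: a 27-fold higher number from compound 1 to compound 3 (1.43 log units; beyond the scatter). Compound 4 `CCN1CCN(c2cc(C)c3cc(NC(=O)c4cc5ccccc5[nH]4)ccc3n2)CC1` differs from compound 3 in one place: 1H-indol-2-yl in place of furan-2-yl on a carbonyl carbon. Within the data shown here, the steps that bear on this are a 17-fold higher number from compound 1 to compound 2 (1.24 log units; beyond the scatter) and a 27-fold higher number from compound 1 to compound 3 (1.43 log units; beyond the scatter): both show a clearly lower number when the group on the carbonyl carbon contained a six-membered aromatic ring of carbon only. Among the measured compounds shown here, the fused five-membered ring with its hydrogen-bond donor has no measured precedent here, so the estimate is broad. Compound 4 is nevertheless expected to move back towards compound 1, by an estimated step of a 6.9-fold lower number from compound 3 to compound 4 (0.84 log units; beyond the scatter), because compound 1 gives 1530 nM with such a six-membered ring in that place. The expected value for compound 4 is 6000 nM, within a range from 1200 nM to 30000 nM.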

Compound 4, half-maximal inhibitory concentration: 2950 nM
Compound 4: the middle estimate sits 2.0-fold (0.31 log units) above what was measured; the range from low to high includes it.
By their numbers in this assay, from the lowest: compounds 1 and 4 (each within the scatter of the next); then compounds 2 and 3 (each within the scatter of the next).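

In this assay, the change from furan-2-yl to 1H-indol-2-yl gives a 14-fold lower number from compound 3 to compound 4 (1.15 log units; beyond the scatter), and the change from pyridin-3-yl to 1H-indol-2-yl gives a 9.0-fold lower number from compound 2 to compound 4 (0.96 log units; beyond the scatter). Among these compounds, replacing 4-chlorophenyl with 1H-indol-2-yl gives a 1.9-fold higher number from compound 1 to compound 4 (0.29 log units; within the scatter), so 4-chlorophenyl is not the only group on the carbonyl carbon that reaches this level, and a chlorine is not required for it. Among these four compounds, the two groups containing a six-membered aromatic ring of carbon only separate from the two without one, and no compound goes against this split.

No measurement here explains this split. As far as these compounds go, it also remains open whether the hydrogen on the indole nitrogen matters, a question that benzofuran-2-yl or 1-methylindol-2-yl in the same place could address.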